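Carboxy-chloro phenyl swap on an isobutyl ketone core

The source may hold more compounds than are shown below. What is called first, only, known or untested is meant among the compounds shown, and "the series" means these compounds.

Measured so far in an assay on HEK293 cells for positive allosteric modulation of metabotropic glutamate receptor 3 (Rattus norvegicus), read by thallium flux, with a stated time of 2.5 min; a higher number here means a larger maximal response, a lower number a smaller maximal response:
- compound 1 `COC(=O)c1ccc(OCCCCOc2ccc(C(=O)CC3CCCC3)c(O)c2C)cc1` gives 22% in this assay.
- compound 2 `Cc1c(OCCCCOc2ccc(C(=O)O)cc2Cl)ccc(C(=O)CC2CCCC2)c1O` gives 27.4% in this assay.
- compound 3 `COC(=O)c1ccc(OCCCCOc2ccc(C(=O)CC(C)C)c(O)c2C)cc1` gives 22.7% in this assay.

Compound 4 `Cc1c(OCCCCOc2ccc(C(=O)O)cc2Cl)ccc(C(=O)CC(C)C)c1O` remains to be measured in this assay.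

The change from compound 3 to compound 4 is 4-carboxy-2-chlorophenyl in place of 4-(methoxycarbonyl)phenyl on an oxygen on a saturated carbon. The same change is made between measured compounds, namely (4-carboxy-2-chlorophenyl in place of 4-(methoxycarbonyl)phenyl on an oxygen on a saturated carbon), and it occurs twice among the four compounds. In this assay that step reads a number 5.4 percentage points higher from compound 1 to compound 2 (within the scatter). The two place lines match word for word, so the change is the same kind of change made at the same kind of position, but on a different core.

The two cores differ as isopropyl in place of cyclopentyl on a saturated chain carbon bound to a carbonyl carbon. In this assay this core change gives a number 0.7 percentage points higher from compound 1 to compound 3 (within the scatter), so the isobutyl core and the cyclopentylmethyl core sit within the scatter of each other in the methoxycarbonyl series. Compound 3 stands within the scatter of both compound 1 and compound 2.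

For the measured compounds named here, with only one earlier instance of the swap and no spread beyond the scatter among the three measured numbers, the expectation for compound 4 is simply that the small step seen from compound 1 to compound 2 repeats, because a number 5.4 percentage points higher from compound 1 to compound 2 (within the scatter) is the only guide available. The expected step is a number 4.8 percentage points higher from compound 3 to compound 4 (within the scatter), of the same small size as the earlier one. Compound 4 is therefore estimated at 27.5% in this assay, with a range of 17% to 38% to cover the scatter.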

Compound 4, largest response reached (reported as percent of maximum), in percent of the reference or control that the assay uses: 62.9%
The estimate for compound 4 lay 35.4 percentage points below the measured number; measured number outside the range, above it.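

In this assay, 4-carboxy-2-chlorophenyl in place of 4-(methoxycarbonyl)phenyl gives a number 40.2 percentage points higher from compound 3 to compound 4 (beyond the scatter), so the size of this step on the isobutyl ketone core is not the size seen on the cyclopentyl core, and this change does not carry over unchanged from one core to the other: the same change on two cores in this assay, a number 5.4 percentage points higher (within the scatter) from compound 1 to compound 2 and a number 40.2 percentage points higher (beyond the scatter) from compound 3 to compound 4, 34.8 percentage points apart, beyond the scatter of two such steps

Read along the other edge, isopropyl in place of cyclopentyl gives a number 35.5 percentage points higher from compound 2 to compound 4 (beyond the scatter), so the two changes do not act independently of each other in these four compounds, and the large response appears only in compound 4, the one compound carrying both: the same change on two cores in this assay, a number 0.7 percentage points higher (within the scatter) from compound 1 to compound 3 and a number 35.5 percentage points higher (beyond the scatter) from compound 2 to compound 4, 34.8 percentage points apart, beyond the scatter of two such steps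

This shows a dependence between the two places within a single set of four compounds, but it does not show why the dependence arises, nor whether it extends to any other group at either place.

The swap alters the ester and the chlorine together, so a 4-carboxyphenyl group without chlorine and a 4-(methoxycarbonyl)-2-chlorophenyl group would be needed to tell which part goes with the large step. From the compounds shown here alone, it also remains open whether a smaller or a more branched group on the ketone chain, such as ethyl or tert-butyl, behaves like the isopropyl or like the cyclopentyl.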